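Pyrazolylethoxy ether at the saturated ring carbon

The compounds below may be only part of what the source reports. "The series", "measured", "known", "first", "only" and "open" are said of these compounds alone.

Measured so far:
compound 1 `Cc1nn(-c2ncnc3nc[nH]c23)c2c1C(OC1CCCC1)CC(=O)N2`: 62 nM
compound 2 `Cc1nn(-c2ncnc3nc[nH]c23)c2c1C(C(=O)NCc1ccccc1)CC(=O)N2`: 2930 nM
compound 3 `Cc1nn(-c2ncnc3nc[nH]c23)c2c1C(C(=O)N(C)c1ccccc1)CC(=O)N2`: 5220 nM

All three share a core and differ only in the group on a saturated ring carbon; the read-out is a functional assay on HEK293 cells for agonist activity at G-protein coupled receptor 39 (Homo sapiens), read by scintillation proximity assay and inositol phosphate accumulation, with a stated time of 75 min; on this read-out higher numbers stand for an effect only at larger amounts of compound and lower numbers for an effect already at smaller amounts. Compound 2 stands second highest of the three numbers. Its nearest neighbour is compound 3, a 1.8-fold higher number from compound 2 to compound 3 (0.25 log units; within the scatter), so these two amides cannot be told apart. Compound 1, the ether, is far away: a 47-fold higher number from compound 1 to compound 2 (1.67 log units; beyond the scatter) and an 84-fold higher number from compound 1 to compound 3 (1.93 log units; beyond the scatter), both large.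

Compound 4 `Cc1nn(-c2ncnc3nc[nH]c23)c2c1C(OCCn1cccn1)CC(=O)N2` carries the change (2-(1H-pyrazol-1-yl)ethoxy in place of benzylcarbamoyl on a saturated ring carbon). Going by the values given here, both prior steps from ether to amide were large and in the same direction, so the reverse move, from an amide back to an ether, bears on this step; the steps from compound 1 to compounds 2 and 3 are the only relevant evidence. Among the compounds with values here, no measured compound carries the 2-(1H-pyrazol-1-yl)ethoxy group or any oxygen substituent other than cyclopentyloxy, so how closely compound 4 will track compound 1 is open.

The expectation for compound 4 is a large step toward lower numbers, a 15-fold lower number from compound 2 to compound 4 (1.17 log units; beyond the scatter), because the ether compound 1 gives 62 nM. Compound 4 is estimated at 200 nM, within 50 nM to 900 nM.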

Compound 4, half-maximal effective concentration: 2270 nM
Compound 4: middle estimate off by 11-fold (1.05 log units), on the low side; the whole stated range lies below it.
By their numbers in this assay, from the lowest: compound 1; then compounds 4, 2 and 3 (each within the scatter of the next, the first and the last beyond it).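

In this assay, the ether link on the saturated ring carbon does not alone go with a low number: placing 2-(1H-pyrazol-1-yl)ethyl instead of cyclopentyl on the oxygen gives a 37-fold higher number from compound 1 to compound 4 (1.56 log units; beyond the scatter), a large step that shows the group on the oxygen matters at this position. Going by these compounds alone, the split between ethers and amides suggested by the earlier compounds therefore does not hold, as the change from benzylcarbamoyl gives a 1.3-fold lower number from compound 2 to compound 4 (0.11 log units; within the scatter), leaving those two compounds indistinguishable, and the change from methyl(phenyl)carbamoyl gives only a modest 2.3-fold lower number from compound 3 to compound 4 (0.36 log units; beyond the scatter), so compound 1 alone stands far from the others. Nothing at hand explains why the two ethers differ so widely.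

Still open, as far as these compounds go, is whether the large step follows from the pyrazole ring, the ethyl link or both, and 2-cyclopentylethoxy would separate these by keeping the chain while restoring the carbocycle. From the compounds shown here alone, it is also open how narrowly the low number depends on cyclopentyloxy itself, a question that smaller and larger ethers such as isopropoxy and cyclohexyloxy would address.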